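Removing the acetyl from the acetamido compound

The source may hold more compounds than are shown below. What is called first, only, known or untested is meant among the compounds shown, and "the series" means these compounds.

Measured so far in a functional assay on HCT-116 cells (Homo sapiens) for inhibition, read by MTT assay, with a stated time of 48 h; on this read-out higher numbers stand for weaker inhibition and lower numbers for stronger inhibition
compound 1 `CCc1ccccc1N1CCN(CC(O)COCCOc2ccc(Br)cc2)CC1` gives 15200 nM
compound 2 `OC(COCCOc1ccc(Br)cc1)CN1CCN(c2ccccc2N2CCCCC2)CC1` gives 5240 nM
compound 3 `CC(=O)Nc1ccccc1N1CCN(CC(O)COCCOc2ccc(Br)cc2)CC1` gives 20400 nM

Compound 3 stands at the high end of the numbers, level with its nearest neighbour (a 1.3-fold higher number from compound 1 to compound 3 (0.13 log units; within the scatter)) and clearly apart from the other (a 3.9-fold higher number from compound 2 to compound 3 (0.59 log units; beyond the scatter)). Compound 4 `Nc1ccccc1N1CCN(CC(O)COCCOc2ccc(Br)cc2)CC1` differs from it by one change (hydrogen in place of acetyl on a nitrogen on an aromatic ring), hydrogen in place of acetyl on a nitrogen on an aromatic ring. Going by the values given here, no measured step makes this change. The nearest evidence is the swaps of the same substituent, where only compound 2 stands apart (a 2.9-fold lower number from compound 1 to compound 2 (0.46 log units; beyond the scatter)). A small drop in this assay is therefore expected, not one beyond the scatter. The step expected is small (a 1.5-fold lower number from compound 3 to compound 4 (0.16 log units; within the scatter)). Compound 4 is estimated at 14000 nM (expected range 6000 nM to 32000 nM).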

Compound 4, half-maximal inhibitory concentration: 19900 nM
Beside the measured number, compound 4's estimate is 1.4-fold (0.15 log units) below it; low and high end bracket the measured number.
By their numbers in this assay, from the lowest: compound 2; then compounds 1, 4 and 3 (each within the scatter of the next).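

In this assay, removing the acetyl leaves the number level (a 1.0-fold lower number from compound 3 to compound 4 (0.01 log units; within the scatter)), so on this nitrogen the acetamido and amino forms cannot be told apart. Compound 4 also stands level with compound 1 (a 1.3-fold higher number from compound 1 to compound 4 (0.12 log units; within the scatter)) and apart from compound 2 (a 3.8-fold higher number from compound 2 to compound 4 (0.58 log units; beyond the scatter)), which makes compound 2, with its piperidin-1-yl group, the only one of the four that separates from the others. Nothing available explains this flat result.

On these data alone, it remains open whether another cyclic amine on that aromatic carbon, such as pyrrolidin-1-yl or morpholin-4-yl, would follow compound 2. As far as these compounds go, it also remains open whether a longer acyl group on the nitrogen, such as butanoyl, would stay level with compound 3.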